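A few compounds are considered here, and "the series" means these few. Any claim that something is new, unique, unknown or untested is made for them only; others in the source may bear on it.

Compound 2 `COc1ccc(C(NC(=O)CNC(=O)c2ccc(F)cc2)c2ccccc2)cc1` gives 1100 nM in an assay for inhibition of sodium- and chloride-dependent glycine transporter 1 (Homo sapiens) (on this read-out higher numbers stand for an effect only at larger amounts of compound and lower numbers for an effect already at smaller amounts), and stands at the highest of the two numbers shown. For the measured compounds named here, its nearest neighbour is compound 1 `O=C(CNC(=O)c1ccc(F)cc1)NC(c1ccccc1)c1ccccc1`, which in this assay gives 110 nM; the one measured step is a 10-fold higher number from compound 1 to compound 2 (1.00 log units; beyond the scatter), arising from methoxy in place of hydrogen on an aromatic carbon. Compound 3 `CCC(NC(=O)CNC(=O)c1ccc(F)cc1)c1ccccc1` is not yet measured. Its change from compound 2 is ethyl in place of 4-methoxyphenyl on a saturated chain carbon bound to an amide-type nitrogen and an aromatic carbon. Going by the values given here, the measured step bears on it only in part: it shows that the methoxy carries the higher number of compound 2, so removing it should lower the number again, but no measured pair shows what the loss of the whole aromatic ring does. Compound 3 is therefore expected to step a 2.8-fold lower number from compound 2 to compound 3 (0.44 log units; beyond the scatter), with the uncertainty wide. For compound 3 the estimate is 400 nM, in a range from 100 nM to 2000 nM.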

Compound 3, half-maximal effective concentration: 4100 nM
Estimate against measurement, compound 3: 10-fold (1.01 log units) below; measured number above the stated range.
By their numbers in this assay, from the lowest: compound 1; then compound 2; then compound 3.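

In this assay, the saturated chain carbon bound to an amide-type nitrogen and an aromatic carbon proves sensitive to the loss of a second aromatic ring: ethyl in place of phenyl gives a 37-fold higher number from compound 1 to compound 3 (1.57 log units; beyond the scatter). Ethyl in place of 4-methoxyphenyl also raises the number, with a 3.7-fold higher number from compound 2 to compound 3 (0.57 log units; beyond the scatter), so the methoxy-bearing ring, despite its higher number than phenyl, still gives a lower number than ethyl. Nothing available explains either step.

The compounds shown leave open whether a ring is needed here or whether a longer chain, such as butyl, could give a similarly low number. They also leave open how a saturated cyclohexyl ring or a pyridine ring would compare with phenyl at this place.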